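This account rests on a few compounds, and the source may have more. Where it says the series, first, only, none or still open, it means among the compounds named here.

Measured compounds:

- Compound 1, `CC1CCN(C2CCN(S(=O)(=O)c3cccc(Br)c3)CC2)CC1`, gives 0.217 h in an ADME assay on S9 fraction from liver (Mus musculus, strain ICR/CD-1) for metabolic stability, read by LC-MS, using NADPH, with a stated time of 5 min, tested at 2 uM; a lower number here means that the compound disappears faster, a higher number that the compound lasts longer.
- Compound 2, `CC1CCN(C2CCN(S(=O)(=O)c3cccc(-c4ccccc4F)c3)CC2)CC1`, gives 0.283 h in this assay.
- Compound 3, `Cc1nc(Cl)sc1S(=O)(=O)N1CCC(N2CCC(C)CC2)CC1`, gives 0.167 h in this assay.

Compound 2 holds the highest of the three numbers, but its neighbours sit close: the step of a 1.3-fold higher number from compound 1 to compound 2 (0.12 log units; within the scatter) lies within the scatter, as does the step of a 1.3-fold lower number from compound 1 to compound 3 (0.11 log units; within the scatter), so none of the three half-lives can be told apart with confidence. All three compounds are short-lived in this preparation.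

Compound 4, `Cc1cc(C)cc(-c2cccc(S(=O)(=O)N3CCC(N4CCC(C)CC4)CC3)c2)c1`, has not yet been measured in this assay. It differs from compound 2 in one place: 3,5-dimethylphenyl in place of 2-fluorophenyl on an aromatic carbon. Within the data shown here, no measured step exchanges one aryl substituent for another at this position; the closest precedent is the step of a 1.3-fold higher number from compound 1 to compound 2 (0.12 log units; within the scatter), which attached an aryl group where a halogen had been and moved the number only within the scatter. The other step, a 1.3-fold lower number from compound 1 to compound 3 (0.11 log units; within the scatter), changed the whole sulfonyl-bearing ring and likewise stayed within the scatter. Among the measured compounds shown here, the numbers so far show that edits to this part of the shared core have left the half-life roughly unchanged, so no step beyond the scatter is expected in this assay, in either direction.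

Compound 4 is therefore estimated at 0.25 h, with a range from 0.1 h to 0.55 h, which corresponds to an expected step of a 1.1-fold lower number from compound 2 to compound 4 (0.05 log units; within the scatter).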

Compound 4, half-life: > 4 h
Compound 4: a limit, no number; the forecaster's own chance of this, stated with the estimate: 5%; middle value at least 16-fold (1.20 log units) away from the limit.
By their numbers in this assay, from the lowest: compounds 3, 1 and 2 (each within the scatter of the next). At a limit, above all of these: compound 4.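

At this position, on an aromatic carbon meta to a large group, the half-life in this assay depends on which aryl group sits there. Exchanging 2-fluorophenyl for 3,5-dimethylphenyl gives an at least 14-fold higher number from compound 2 to compound 4 (1.15 log units; beyond the scatter), whereas the earlier exchange of bromo for 2-fluorophenyl stayed within the scatter. Measured against bromo, 3,5-dimethylphenyl gives an at least 18-fold higher number from compound 1 to compound 4 (1.26 log units; beyond the scatter), so having an aryl group here is not enough on its own, as compound 2 shows, and the particular aryl group matters; the reading for compound 4 is a limit and not a number, so both steps are minimum sizes only: the limit of > 4 h in this assay, at which 1 of the 4 values shown sits.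

This swap removes a fluorine and adds methyl groups in one move, and the compounds shown cannot tell which of these carries the step, a question that an unsubstituted phenyl ring could help to settle. They also leave open how far the half-life of compound 4 extends past the limit, and whether the same ring would hold its result when bearing a methoxy group, an amine or a carboxylic acid.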